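One Chloro Group, Two Cores: Estimating Compound 4

The compounds below may be only part of what the source reports. "The series", "measured", "known", "first", "only" and "open" are said of these compounds alone.

Compound 1, `COc1ccc(CNC(=O)/C(C#N)=C/c2ccco2)cc1`, gives 33000 nM in a functional assay on SMA cells (Homo sapiens) for inhibition, read by MTT assay, with a stated time of 72 h; on this read-out lower numbers stand for stronger inhibition of growth and higher numbers for weaker inhibition of growth.
Compound 2, `COc1ccc(CNC(=O)/C(C#N)=C/c2ccc(Cl)o2)cc1`, gives 14000 nM in this assay.
Compound 3, `N#C/C(=C\c1ccccc1)C(=O)NCc1ccc(Cl)c(Cl)c1`, gives 43000 nM in this assay.

Compound 1 and compound 3 have different cores, and the difference between the two cores is not broken down here; their values lie within the scatter of each other. Compound 2 arises from compound 1 by chloro in place of hydrogen on an aromatic carbon, and this change brought a 2.4-fold lower number from compound 1 to compound 2 (0.37 log units; beyond the scatter) in this assay.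

Compound 4, `N#C/C(=C\c1ccc(Cl)cc1)C(=O)NCc1ccc(Cl)c(Cl)c1`, has not yet been measured. It arises from compound 3 by chloro in place of hydrogen on an aromatic carbon. This is the same kind of change as from compound 1 to compound 2, but the place differs: there the chloro sits on a five-membered aromatic ring with one oxygen, next to the ring oxygen; here it sits on a six-membered aromatic ring of carbon only, para to a large group. Resting on compound 3 at 43000 nM and on the earlier step, a similar step is expected, a 2.2-fold lower number from compound 3 to compound 4 (0.33 log units; beyond the scatter) in this assay. Compound 4 is therefore estimated at 20000 nM, likely between 9000 nM and 45000 nM.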

Compound 4, concentration for 50% growth inhibition: 33000 nM
Beside the measured number, compound 4's estimate is 1.7-fold (0.22 log units) below it, and the stated range covers the measured number.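

Replacing phenyl with 4-chlorophenyl brought a 1.3-fold lower number from compound 3 to compound 4 (0.11 log units; within the scatter) in this assay, so on this core the change cannot be told apart from the differences seen between repeated measurements. Set beside the earlier step, the new one does not differ from it by more than the scatter of two such steps allows: the same change on two cores in this assay, a 2.4-fold lower number (0.37 log units; beyond the scatter) from compound 1 to compound 2 and a 1.3-fold lower number (0.11 log units; within the scatter) from compound 3 to compound 4, 1.8-fold (0.26 log units) apart, within the scatter of two such steps. Going by these compounds alone, this means the result fits the change carrying over from one core to the other, but it does not prove that it does, since there are only two pairs and just one of the steps lies beyond the scatter.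

The compounds shown leave open whether chloro is special or whether another group in the same place, such as a fluoro, a methyl or an amine, would give a similar or larger step. They also leave open which parts of the two cores set their values, since those cores differ in more than one place and no compounds shown separate those differences.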